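A few compounds are considered here, and "the series" means these few. Any claim that something is new, unique, unknown or untested is made for them only; others in the source may bear on it.

Working notes on the series. Of the compounds shown here, two carry numbers so far. In an assay on brain (strain Sprague-Dawley) for displacement of a labelled ligand from sodium-dependent dopamine transporter (Rattus norvegicus), read by scintillation counting, with a stated time of 120 min (on this read-out lower numbers stand for stronger inhibition and higher numbers for weaker inhibition), compound 1 `CCCCNC(=O)CSC(c1ccccc1)c1ccccc1` gives 23600 nM, the larger of the two numbers recorded. In this assay compound 2 `Cc1ccc(C(c2ccc(C)cc2)[S+]([O-])CC(N)=O)cc1` gives 12700 nM, and this value sits within the scatter of that of compound 1. Compound 3 `CNC(=O)CSC(c1ccccc1)c1ccccc1` is not yet measured; it differs from compound 1 by hydrogen in place of propyl on a saturated chain carbon bound to an amide-type nitrogen. For the measured compounds named here, no measured pair shows this change, so the step is expected to stay within the scatter, with no firm direction. Compound 3 is therefore estimated at 30000 nM in this assay, within a range from 8000 nM to 100000 nM, which corresponds to an expected step of a 1.3-fold higher number from compound 1 to compound 3 (0.10 log units; within the scatter).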

Compound 3, inhibition constant: 19300 nM
Compound 3: the middle estimate sits 1.6-fold (0.19 log units) above what was measured, and the stated range covers the measured number.
By their numbers in this assay, from the lowest: compounds 2, 3 and 1 (each within the scatter of the next).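

In this assay, for the compounds shown here, this is the first measured pair for the change at this position: hydrogen in place of propyl on a saturated chain carbon bound to an amide-type nitrogen gives a 1.2-fold lower number from compound 1 to compound 3 (0.09 log units; within the scatter), so the butylcarbamoyl and methylcarbamoyl forms are not told apart here. The chain on the amide nitrogen can thus be cut from butyl to methyl with the number staying within the scatter. No evidence on hand bears on this result. Still open, on these data alone, is whether a terminal amine, a carboxylic acid or a phenyl ring at this position would shift the number beyond the scatter. Also open, as far as these compounds go, is whether a chain longer than butyl would do so.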